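Swapping a 3-fluorophenyl for a 4-bromophenyl: expected activity

This account rests on a few compounds, and the source may have more. Where it says the series, first, only, none or still open, it means among the compounds named here.

Compound 2 `Nc1scc(-c2cccc(F)c2)c1C(=O)c1ccccc1` gives 52% in a functional assay on CHO cells for agonist activity at adenosine receptor A1 (Homo sapiens), read by fluorescence and ERK phosphorylation, with stated times of 30 min and 1.5 h, tested at 10 uM; on this read-out lower numbers stand for a weaker effect and higher numbers for a stronger effect at the one concentration tested. Compound 3 `Nc1scc(-c2cccc(Cl)c2)c1C(=O)c1ccccc1` gives 52%, and the two stand level within the scatter; compound 1 `Nc1scc(-c2ccccc2F)c1C(=O)c1ccccc1` gives 68%, so compound 2 and compound 3 together hold the lowest of the three numbers. Compound 4 `Nc1scc(-c2ccc(Br)cc2)c1C(=O)c1ccccc1` differs from compound 2 by 4-bromophenyl in place of 3-fluorophenyl on an aromatic carbon. Going by the values given here, two measured steps bear on this. Exchanging one halogen for another at an unchanged place gave no change at the digits printed from compound 2 to compound 3 (within the scatter), whereas shifting where the fluorine sits gave a number 16 percentage points lower from compound 1 to compound 2 (beyond the scatter). Among the compounds with values here, no measured pair places a halogen where compound 4 carries its bromine, so the outcome is uncertain; a step within the scatter or a modest fall is expected, a number 7 percentage points lower from compound 2 to compound 4 (within the scatter). Compound 4 is therefore estimated at 45%, within 25% to 65%.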

Compound 4, a percentage reported as activity, at one concentration (the size of the read-out at that concentration, not a potency): 49%
Compound 4: the middle estimate sits 4 percentage points below what was measured; the range from low to high includes it.
By their numbers in this assay, from the lowest: compounds 4, 2 and 3 (each within the scatter of the next); then compound 1.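

In this assay, 4-bromophenyl reads level with the two groups it was compared with, a number 3 percentage points lower from compound 2 to compound 4 (within the scatter) and a number 3 percentage points lower from compound 3 to compound 4 (within the scatter). The gap to the 2-fluorophenyl group remains, a number 19 percentage points lower from compound 1 to compound 4 (beyond the scatter), so among these four compounds only compound 1 stands apart. Nothing measured here explains these readings.

From the compounds shown here alone, the step to compound 4 changes both the halogen and its place on the phenyl ring, so the share of each stays open. Also open, going by these compounds, is how an amine or a carboxylic acid on that ring would read.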